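The source may report more compounds than this note shows. Statements on the series, on what has been measured and on what is new or still open speak of the compounds shown alone.

Measured in a functional assay on HepG2 cells (Homo sapiens) for inhibition, read by MTT assay, with a stated time of 72 h; on this read-out lower numbers stand for stronger inhibition and higher numbers for weaker inhibition:
- compound 1 `O=C1/C(=C\c2ccccc2)c2c(ncn2COCc2ccccc2)CCN1Cc1ccccc1`: 13900 nM
- compound 2 `O=C1/C(=C\c2ccccc2)c2c(ncn2COCc2ccccc2)CCN1Cc1ccc(F)cc1`: 39400 nM
- compound 3 `Cc1cc(C)cc(CN2CCc3ncn(COCc4ccccc4)c3/C(=C/c3ccccc3)C2=O)c1`: 40900 nM

Compound 2 belongs to the upper pair of these three numbers and cannot be separated from compound 3, as a 1.0-fold higher number from compound 2 to compound 3 (0.02 log units; within the scatter) shows. Compound 1 lies clearly lower, with a 2.8-fold higher number from compound 1 to compound 2 (0.45 log units; beyond the scatter).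

The next compound is compound 4 `CC(C)(C)c1ccc(CN2CCc3ncn(COCc4ccccc4)c3/C(=C/c3ccccc3)C2=O)cc1`, which has not yet been measured. It differs from compound 2 as follows: tert-butyl in place of fluoro on an aromatic carbon. In words, this is tert-butyl in place of fluoro on an aromatic carbon, para to a large group, or 4-fluorobenzyl to 4-(tert-butyl)benzyl.

Among the measured compounds shown here, no measured step involves tert-butyl, so the evidence is indirect. Two steps away from the unsubstituted phenyl are modest and point the same way: a 2.8-fold higher number from compound 1 to compound 2 (0.45 log units; beyond the scatter) and a 2.9-fold higher number from compound 1 to compound 3 (0.47 log units; beyond the scatter). The closest guide is the exchange of 4-fluorophenyl for 3,5-dimethylphenyl, which gives a 1.0-fold higher number from compound 2 to compound 3 (0.02 log units; within the scatter). On these three compounds, changing one substituted phenyl for another has not moved the number, so no step beyond the scatter is expected in this assay.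

The expected step is a 1.0-fold higher number from compound 2 to compound 4 (0.01 log units; within the scatter).

For compound 4 the estimated value is 40000 nM, with an expected range of 17000 nM to 90000 nM.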

Compound 4, half-maximal inhibitory concentration: 18000 nM
Beside the measured number, compound 4's estimate is 2.2-fold (0.35 log units) above it, and the stated range covers the measured number.
By their numbers in this assay, from the lowest: compounds 1 and 4 (each within the scatter of the next); then compounds 2 and 3 (each within the scatter of the next).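

In this assay the substituted benzyl groups no longer sit at one level, so substitution on this aromatic ring does not by itself go with a higher number: tert-butyl in place of fluoro gives a modest drop (a 2.2-fold lower number from compound 2 to compound 4 (0.34 log units; beyond the scatter)), and 4-(tert-butyl)phenyl in place of 3,5-dimethylphenyl gives a similar one (a 2.3-fold lower number from compound 3 to compound 4 (0.36 log units; beyond the scatter)). Compared with the unsubstituted phenyl, tert-butyl cannot be told apart (a 1.3-fold higher number from compound 1 to compound 4 (0.11 log units; within the scatter)), so compound 4 goes against the pattern suggested by compound 2 and compound 3, and a group of four heavy atoms at this place costs nothing measurable against hydrogen. No measured property of these groups is available to account for this difference.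

On these data alone, with only fluoro and tert-butyl at this place, it remains open whether the number follows the particular group, and a methoxy, an amine such as dimethylamino or a carboxylic acid there would test this. The shown compounds also leave open how this substituent behaves once the benzyloxymethyl group or the unsubstituted phenyl of the benzylidene is exchanged, for instance for a longer chain or a pyridine.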